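The compounds below may be only part of what the source reports. "The series", "measured", "known", "first", "only" and "open" are said of these compounds alone.

Measured compounds: compound 1 `Cc1cc(C)c(CN2CCc3c(Cl)cc([C@H](C)CO)c(Cl)c3C2=O)c(=O)[nH]1` gives 17 nM in an assay for inhibition of histone-lysine N-methyltransferase EZH2 variant Y641N (Homo sapiens), read by scintillation counting, with a stated time of 60 min, in the presence of a further agent that is not named here; a higher number here means a weaker inhibitor, a lower number a stronger inhibitor; compound 2 `Cc1cc(C)c(CN2CCc3c(Cl)cc(C(CO)C4CCOC4)c(Cl)c3C2=O)c(=O)[nH]1` gives 150 nM; 0.38 nM (2 entries); compound 3 `Cc1cc(C)c(CN2CCc3c(Cl)cc([C@@H](C)CO)c(Cl)c3C2=O)c(=O)[nH]1` gives 260 nM.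

Compound 3 stands highest of the two single numbers; the nearest is compound 1, and the step of a 15-fold higher number from compound 1 to compound 3 (1.18 log units; beyond the scatter) rests on configuration alone (the fact that compounds 1 and 3 differ only in the configuration as drawn). Compound 4 `Cc1cc(C)c(CN2CCc3c(Cl)cc([C@@H](CO)[C@H]4CCCO4)c(Cl)c3C2=O)c(=O)[nH]1` differs from compound 3 by a group of 8 heavy atoms (6 carbon, 2 oxygen; one five-membered non-aromatic ring with 1 hetero atom) in place of a group of 4 heavy atoms (3 carbon, 1 oxygen; no ring), on an aromatic carbon. Among the compounds with values here, no measured step covers this exact change; the closest comparison is compound 2, whose two entries the several entries of compound 2 in this assay, 150 nM; 0.38 nM (2 entries) spread widely and leave the direction open. Given the single-configuration step from compound 1 to compound 3, a large move is plausible. Compound 4 is expected at 40 nM in this assay, within 2 nM to 600 nM, a step of a 6.5-fold lower number from compound 3 to compound 4 (0.81 log units; beyond the scatter) that is estimated, not measured.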

Compound 4, inhibition constant in the histone-lysine N-methyltransferase EZH2 assay: 110 nM
Estimate against measurement, compound 4: 2.8-fold (0.44 log units) below; low and high end bracket the measured number.
By their numbers in the histone-lysine N-methyltransferase EZH2 assay, from the lowest: compound 1; then compound 4; then compound 3.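

In the histone-lysine N-methyltransferase EZH2 assay compound 4, with the chain bearing oxolan-2-yl on this aromatic carbon, gives 110 nM, a number between those of the two methyl-bearing compounds, with modest steps on either side (a 2.4-fold lower number from compound 3 to compound 4 (0.37 log units; beyond the scatter)) and (a 6.5-fold higher number from compound 1 to compound 4 (0.81 log units; beyond the scatter)). A group of this size is therefore accepted here, though compound 4 does not match compound 1. In a physicochemical assay for lipophilicity, at pH 7.4 (a higher number here means a more lipophilic compound, a lower number a more polar compound), compound 3 gives 2.5 and compound 4 gives 2.5, so the same change shows no shift (no change at the digits printed from compound 3 to compound 4 (within the scatter)).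

Still open, from the compounds shown here alone, is how other configurations of the oxolan-2-yl chain read in the histone-lysine N-methyltransferase EZH2 assay. Also open, going by these compounds, is whether an amine or a carboxylic acid in place of methyl on the chain would be accepted.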